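A few compounds are considered here, and "the series" means these few. Any claim that something is new, unique, unknown or untested is made for them only; others in the source may bear on it.

Measured so far:
Compound 1, `CCOCCON1C(=O)[C@@H](NC(=O)OCCCCC2CCCCC2)[C@@H]1C`, gives 187 nM in an assay on HEK293 cells for inhibition of N-acylethanolamine-hydrolyzing acid amidase (Homo sapiens), read by fluorescence, with stated times of 10 min and 50 min; on this read-out lower numbers stand for stronger inhibition and higher numbers for weaker inhibition.
Compound 2, `C[C@H]1[C@H](NC(=O)OCCCCC2CCCCC2)C(=O)N1Oc1ccccc1`, gives 23 nM in this assay.

Within the data shown here, compound 2 stands at the lowest of the two numbers; the only neighbour is compound 1, and the single measured step, an 8.1-fold lower number from compound 1 to compound 2 (0.91 log units; beyond the scatter), lies beyond the scatter and concerns the group on the oxygen. Compound 3, `C[C@H]1[C@H](NC(=O)OCCCCC2CCCCC2)C(=O)N1Oc1ccc(S(C)(=O)=O)cc1`, arises from compound 2 by methylsulfonyl in place of hydrogen on an aromatic carbon. Among the measured compounds shown here, no measured step touches this position: the one step known alters what sits on the oxygen as a whole, not a substituent on the phenyl, so it gives no direct guide. With nothing in the data pointing either way, the change in this assay is expected to stay within the scatter, a 1.3-fold higher number from compound 2 to compound 3 (0.12 log units; within the scatter). Compound 3 is therefore estimated at 30 nM in this assay, with a range from 8 nM to 120 nM.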

Compound 3, half-maximal inhibitory concentration in the N-acylethanolamine-hydrolyzing acid amidase assay: 6 nM
Compound 3: middle estimate off by 5.0-fold (0.70 log units), on the high side; the whole stated range lies above it.
By their numbers in the N-acylethanolamine-hydrolyzing acid amidase assay, from the lowest: compound 3; then compound 2; then compound 1.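

In the N-acylethanolamine-hydrolyzing acid amidase assay, the aromatic carbon para to a large group turns out to matter: the earlier step changed the whole group on the oxygen, whereas this one adds methylsulfonyl to an otherwise unchanged phenyl and gives a 3.8-fold lower number from compound 2 to compound 3 (0.58 log units; beyond the scatter). The full replacement of 2-ethoxyethyl by 4-(methylsulfonyl)phenyl on the oxygen gives a 31-fold lower number from compound 1 to compound 3 (1.49 log units; beyond the scatter), so the change to phenyl and the added methylsulfonyl both point the same way across these compounds. In a physicochemical assay for metabolic stability, read by HPLC, in phosphate buffer, with a stated time of 24 h, at 37 degrees C, at pH 7.4, tested at 1 uM, in the presence of a further agent that is not named here (on this read-out higher numbers stand for a longer-lived compound and lower numbers for a shorter-lived compound), compound 2 gives > 24 h, which is a limit of the assay and not a number.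

On these data alone, in the physicochemical assay compound 3 gives 12.1 h, and an at least 1.9-fold lower number from compound 2 to compound 3 (0.29 log units; that floor lies within the scatter) leaves open whether methylsulfonyl shifts the half-life at all: the limit of > 24 h in the physicochemical assay, at which 1 of the 2 values shown sits. Also open is whether the lower number belongs to methylsulfonyl itself, or would also come with an amine, a carboxylic acid or fluorine at this place.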